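Neopentyl for sec-Butyl on the Amide Nitrogen

A few compounds are considered here, and "the series" means these few. Any claim that something is new, unique, unknown or untested is made for them only; others in the source may bear on it.

Three compounds of one series have been characterised in a functional assay on CHO cells for positive allosteric modulation of muscarinic acetylcholine receptor M5 (Homo sapiens), read by calcium flux; a higher number here means a larger maximal response, a lower number a smaller maximal response. Compound 1 `CCCN(Cc1ccccc1C(F)(F)F)C(=O)C1CCN(S(=O)(=O)c2ccc3[nH]ncc3c2)CC1` gives 94% in this assay. Compound 2 `O=C(C1CCN(S(=O)(=O)c2ccc3[nH]ncc3c2)CC1)N(Cc1ccccc1C(F)(F)F)C1CC1` is recorded in this assay as "not determined" (no result reported). Compound 3 `CCC(C)N(Cc1ccccc1C(F)(F)F)C(=O)C1CCN(S(=O)(=O)c2ccc3[nH]ncc3c2)CC1` gives 100% in this assay, which is the highest of the two numbers available, with compound 1 as its nearest neighbour; the step of a number 6 percentage points higher from compound 1 to compound 3 (within the scatter) lies within the scatter, so the two cannot be ordered.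

Compound 4 `CC(C)(C)CN(Cc1ccccc1C(F)(F)F)C(=O)C1CCN(S(=O)(=O)c2ccc3[nH]ncc3c2)CC1` has not yet been measured. It differs from compound 3 in one place: neopentyl in place of sec-butyl on an amide-type nitrogen. For the measured compounds named here, the only measured step, a number 6 percentage points higher from compound 1 to compound 3 (within the scatter), also changes the chain on the amide-type nitrogen and did not move the maximal response beyond the scatter. On that basis no step beyond the scatter is expected in this assay for the move from compound 3 to compound 4, although the new chain is larger than any chain tried so far. Compound 4 is therefore estimated to give 94% in this assay, between 78% and 106%, which means an expected step of a number 6 percentage points lower from compound 3 to compound 4 (within the scatter).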

Compound 4, largest response reached (reported as percent of maximum), in percent of the reference or control that the assay uses: 104%
For compound 4 the middle estimate is 10 percentage points below the measured one, within the range that was stated.
By their numbers in this assay, from the lowest: compounds 1, 3 and 4 (each within the scatter of the next).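

In this assay, neopentyl in place of sec-butyl on the amide-type nitrogen gives a number 4 percentage points higher from compound 3 to compound 4 (within the scatter), so a chain of 5 heavy atoms extends the series without a step beyond the scatter. The widest gap in the series, a number 10 percentage points higher from compound 1 to compound 4 (within the scatter), also stays inside the scatter, so the propyl, sec-butyl and neopentyl chains cannot be ordered by maximal response, and none of the three goes against this flat picture. Nothing available explains why the response stays level across these chains.

Steps to compound 2 cannot be read, which leaves the cyclopropyl group on this nitrogen without a comparison. As far as these compounds go, it also remains open whether a chain carrying an amine or a carboxylic acid at this position would keep the maximal response at this level.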